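This account rests on a few compounds, and the source may have more. Where it says the series, first, only, none or still open, it means among the compounds named here.

Compound 2, `C[C@H](Nc1ncnc(N)c1C#N)c1nc2ccc(F)cc2c(C(=O)N(C)C)c1-c1ccccc1`, gives 545 nM in an assay on Sf9 cells for inhibition of phosphatidylinositol 4,5-bisphosphate 3-kinase catalytic subunit beta isoform (Homo sapiens), with a stated time of 20 min; a higher number here means a weaker inhibitor, a lower number a stronger inhibitor. Among the two compounds measured so far, compound 2 carries the lowest number; its nearest neighbour is compound 1, `C[C@H](Nc1ncnc(N)c1C#N)c1nc2ccc(F)cc2c(C(N)=O)c1-c1ccccc1`, which in this assay gives 3540 nM. Among the compounds with values here, the single measured step joining them, a 6.5-fold lower number from compound 1 to compound 2 (0.81 log units; beyond the scatter), is the only guide available for the change now in question. Compound 3, `C[C@H](Nc1ncnc(N)c1C#N)c1nc2ccc(F)cc2c(C(=O)N2CC(O)C2)c1-c1ccccc1`, differs from compound 2 in one place: 3-hydroxyazetidin-1-yl in place of dimethylamino on a carbonyl carbon. The measured step bears on it only in part. Within the data shown here, it shows that the move from amino to dimethylamino on the carbonyl carbon lowered the number, and compound 3 keeps a fully substituted amide nitrogen, but the entering group brings a four-membered ring with a hydroxyl, and no measured step speaks to that. The expectation is therefore that compound 3 stays close to compound 2, with a 1.0-fold higher number from compound 2 to compound 3 (0.00 log units; within the scatter) not reaching beyond the scatter in either direction. The estimate for compound 3 in this assay is 550 nM, within a range from 200 nM to 1600 nM.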

Compound 3, half-maximal inhibitory concentration: 2720 nM
The estimate for compound 3 lay 4.9-fold (0.69 log units) below the measured number, and the stated range ends below it.
By their numbers in this assay, from the lowest: compound 2; then compounds 3 and 1 (each within the scatter of the next).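

On this carbonyl carbon, a fully substituted amide nitrogen does not by itself keep the lower number in this assay: 3-hydroxyazetidin-1-yl in place of dimethylamino gives a 5.0-fold higher number from compound 2 to compound 3 (0.70 log units; beyond the scatter), about as large as the earlier step from amino to dimethylamino, but in the opposite direction. Set against the amino group of the first compound, the same entering group gives a 1.3-fold lower number from compound 1 to compound 3 (0.11 log units; within the scatter), so compound 3 and compound 1 cannot be told apart here, and among these three compounds only the dimethylamino group of compound 2 stands apart, with compound 3 going against any reading that substitution on the amide nitrogen alone sets the number. No measurement is at hand that explains why this group behaves as it does.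

The change brings in the four-membered ring and the hydroxyl together, and the compounds shown leave open which of the two goes with the higher number. Plain azetidin-1-yl without the hydroxyl would separate them, and an open chain such as N-methyl-2-hydroxyethylamino would test the hydroxyl without the ring.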